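The compounds below may be only part of what the source reports. "The series", "measured", "known", "first", "only" and "open" are said of these compounds alone.

Of the compounds shown here, three have been measured in a functional assay on K562 cells (Homo sapiens) for cytotoxicity, read by trypan blue exclusion, with a stated time of 96 h; on this read-out higher numbers stand for weaker inhibition and lower numbers for stronger inhibition. Compound 1 `COc1ccc(/C=C/S(=O)(=O)Cc2ccc(OC)c(N)c2)c(OC)c1` gives 500 nM. Compound 2 `COc1cc(OC)c(/C=C/S(=O)(=O)Cc2ccc(OC)c(N)c2)c(OC)c1`, which carries one methoxy more on the styryl ring, gives 2.5 nM, and compound 3 `COc1cc(OC)c(/C=C/S(=O)(=O)Cc2ccc(Cl)c(N)c2)c(OC)c1` gives 10 nM. The step of a 200-fold lower number from compound 1 to compound 2 (2.30 log units; beyond the scatter) was large, and the step of a 4.0-fold higher number from compound 2 to compound 3 (0.60 log units; beyond the scatter) was modest. Compound 2 therefore holds the lowest number of the three, with compound 3 its nearest neighbour and compound 1 far away.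

Compound 4 `COc1cc(OC)c(/C=C/S(=O)(=O)Cc2ccc(OC)c(N[C@@H](C)C(=O)O)c2)c(OC)c1` departs from compound 2 by 1-carboxyethyl in place of hydrogen on a nitrogen on an aromatic ring. Neither measured step touches the nitrogen: both alter a substituent on one of the aromatic rings, so they show only that this assay responds strongly to changes in the shared core while saying nothing about a group added on the nitrogen. Going by the values given here, with no direct precedent, a moderate rise is the cautious expectation, as a step of an 8.0-fold higher number from compound 2 to compound 4 (0.90 log units; beyond the scatter). Compound 4 is accordingly estimated to give 20 nM, within a range from 4 nM to 100 nM.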

Compound 4, half-maximal inhibitory concentration: 15 nM
Compound 4: the middle estimate sits 1.3-fold (0.12 log units) above what was measured; the measured number falls inside the stated range.
By their numbers in this assay, from the lowest: compound 2; then compounds 3 and 4 (each within the scatter of the next); then compound 1.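

Both earlier steps changed a substituent on an aromatic ring, so the amino group itself had remained untested. Here, 1-carboxyethyl in place of hydrogen on that nitrogen gives a 6.0-fold higher number from compound 2 to compound 4 (0.78 log units; beyond the scatter) in this assay and counts as a modest step, which shows that this assay does respond to a change at the nitrogen. It also shows that the nitrogen can carry a group of 5 heavy atoms, including a carboxylic acid and a defined stereocentre, at the price of a modest loss and not a large one, although nothing available explains the size of this step.

Still open, from the compounds shown here alone, is whether the acid or simply the added chain sets this step, which a methyl ester or a plain ethyl group on the nitrogen could separate. The opposite stereocentre and a longer chain ending in a carboxylic acid also remain to be compared with compound 4.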